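This account rests on a few compounds, and the source may have more. Where it says the series, first, only, none or still open, it means among the compounds named here.

Series notes, metabolic stability.

Of the compounds shown here, two have been measured so far. Compound 1 `COc1ccc2[nH]c(C(=O)N3CC(=O)N(Cc4ccccc4)[C@@H](CCc4ccccc4)C3)cc2c1` and compound 2 `COc1ccc2[nH]c(C(=O)N3CC(=O)N(Cc4ccc[nH]4)[C@@H](Cc4ccccc4)C3)cc2c1` share the same core and differ at the amide substituent and the side chain on the ring carbon. In an ADME assay on microsomes from liver (Homo sapiens) for metabolic stability, with a stated time of 30 min, tested at 1 uM (a lower number here means that the compound disappears faster, a higher number that the compound lasts longer), compound 1 gives 0.167 h, the lower of the two numbers. In this assay compound 2 gives 0.267 h; the gap between compound 1 and compound 2 is within the scatter, so nothing is made of it. Both half-lives are short.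

Compound 3 `COc1ccc2[nH]c(C(=O)N3CC(=O)N(Cc4ccccc4)[C@@H](CN4CC5CCCCC5C4)C3)cc2c1` is the next compound to be measured. It differs from compound 1 at one place: a group of 9 heavy atoms (8 carbon, 1 nitrogen; one five-membered non-aromatic ring with 1 hetero atom, one six-membered non-aromatic ring of carbon only) in place of a group of 7 heavy atoms (7 carbon; one six-membered aromatic ring of carbon only), on a saturated chain carbon bound to a saturated ring carbon. Among the compounds with values here, no measured pair carries a comparable change, so the expected size of the step rests on compound 1 alone. With compound 1 at 0.167 h, the step of a 1.0-fold higher number from compound 1 to compound 3 (0.01 log units; within the scatter) is expected to stay within the scatter, with no direction assumed. Compound 3 is therefore expected at 0.17 h, with a range of 0.07 h to 0.4 h. The measured value for compound 3 in this assay follows.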

Compound 3, half-life: 0.233 h
Compound 3: middle estimate off by 1.4-fold (0.14 log units), on the low side; low and high end bracket the measured number.
By their numbers in this assay, from the lowest: compounds 1, 3 and 2 (each within the scatter of the next).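

In this assay, replacing the benzyl, on a saturated chain carbon bound to a saturated ring carbon, with the group of 9 heavy atoms (one five-membered non-aromatic ring with 1 hetero atom, one six-membered non-aromatic ring of carbon only) gives a 1.4-fold higher number from compound 1 to compound 3 (0.14 log units; within the scatter) as the first step measured at this position. At this place, then, a six-membered aromatic ring of carbon only can give way to two non-aromatic rings with 1 hydrogen-bond acceptor without a change beyond the scatter, and the half-life of compound 3 remains short at 0.233 h in this series. No available data bear on what lies behind this result.

A single pair cannot separate the contribution of the ring nitrogen from that of the loss of the aromatic ring, or show whether the result holds with other groups on the shared core. From the compounds shown here alone, it also remains open whether a different group at this place, such as a primary amine, a carboxylic acid or a longer alkyl chain, would move the half-life beyond the scatter.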